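A few compounds are considered here, and "the series" means these few. Any claim that something is new, unique, unknown or untested is made for them only; others in the source may bear on it.

Compound 1 `O=C(NCc1ccccc1)[C@@H]1CCC(=O)N1Cc1ccccc1`: > 5000 nM
Compound 2 `O=C(O)c1ccc(COc2ccc(CNC(=O)[C@H]3CCC(=O)N3Cc3ccccc3)cc2)cc1`: > 5000 nM
Compound 3 `O=C(O)c1ccc(COc2ccc(CNC(=O)[C@@H]3CCC(=O)N3Cc3ccc(Br)cc3)cc2)cc1`: > 5000 nM

Of the compounds shown here, three have so far been tested in an assay on HEK293 cells for inhibition of Ataxin-2 (Mus musculus), read by fluorescence and Amplex Red; a lower number here means a stronger inhibitor, a higher number a weaker inhibitor. For compound 1 the value > 5000 nM is a limit of the assay and not a number. For compound 2 the value > 5000 nM is likewise a limit. For compound 3 the value > 5000 nM is again a limit. For the measured compounds named here, compound 3 thus stands at the limit of > 5000 nM in this assay, at which 3 of the 3 values shown sit, and the two other compounds sit there with it, so no measured step between any pair can be sized and no compound can be set apart from the others.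

The next compound, compound 4 `O=C1CC[C@@H](C(=O)NCc2ccc(OCc3ccc(C(=O)O)cc3)cc2)N1`, has not yet been measured in this assay. It differs from compound 3 in one place: hydrogen in place of 4-bromobenzyl on an amide-type nitrogen in a ring. Going by the values given here, since every value so far is a limit, the numbers give no footing for a step in either direction; all that can be said is that none of the changes among compounds 1, 2 and 3 brought any of them to a measurable number. Compound 4 is expected to stay at or beyond that limit as well, with an expected step that the limit leaves unreadable from compound 3 to compound 4, meaning no change beyond the scatter. The estimate for compound 4 is 10000 nM, within a range from 3000 nM to 50000 nM.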

Compound 4, half-maximal inhibitory concentration: > 5000 nM
Compound 4: a limit, no number (the forecaster's own chance of this, stated with the estimate: 85%); the middle value is on the limit's open side.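

In this assay compound 4 gives > 5000 nM, which is a limit and not a number. Compound 3 also stands at a limit, and the step to compound 4, hydrogen in place of 4-bromobenzyl, cannot be read. The compounds shown leave open which structural change, if any, would give a measurable number: the limit of > 5000 nM in this assay, at which 4 of the 4 values shown sit.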